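The source may hold more compounds than are shown below. What is called first, only, known or untested is meant among the compounds shown, and "the series" means these compounds.

Three compounds built on one shared core differ only in the aromatic group attached to the five-membered aromatic ring with two nitrogen and one sulfur. Compound 1 `COc1ccc2c(OCc3nnc4sc(-c5cc[nH]c5)nn34)ccnc2c1` carries a 1H-pyrrol-3-yl group, and in a functional assay on EBC-1 cells (Homo sapiens) for antiproliferative activity, with a stated time of 72 h (a lower number here means a stronger inhibitor, a higher number a weaker inhibitor), compound 1 gives 353 nM. Compound 2 `COc1ccc2c(OCc3nnc4sc(-c5cc6ccccc6n5C)nn34)ccnc2c1` carries a 1-methyl-1H-indol-2-yl group, and in this assay compound 2 gives 149 nM. Compound 3 `COc1ccc2[nH]c(-c3nn4c(COc5ccnc6cc(OC)ccc56)nnc4s3)cc2c1` carries a 5-methoxy-1H-indol-2-yl group, and in this assay compound 3 gives 85.6 nM, the lowest of the three numbers; its gap to compound 2 lies within the scatter, while its gap to compound 1 lies beyond it.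

Compound 4 `COc1ccc2c(OCc3nnc4sc(-c5ccncc5)nn34)ccnc2c1` has not yet been measured. The change from compound 3 is pyridin-4-yl in place of 5-methoxy-1H-indol-2-yl on an aromatic carbon. The measured steps that bear on this are a 4.1-fold lower number from compound 1 to compound 3 (0.62 log units; beyond the scatter) and a 2.4-fold lower number from compound 1 to compound 2 (0.37 log units; beyond the scatter), both showing that the two-ring indol-2-yl groups give lower numbers than the single five-membered ring, while a 1.7-fold lower number from compound 2 to compound 3 (0.24 log units; within the scatter) shows the two indol-2-yl groups within the scatter of each other. Compound 4 returns to a single small ring, now with no hydrogen-bond donor. Since compound 1 with its single small ring gives 353 nM, a step back upward is expected, namely a 5.3-fold higher number from compound 3 to compound 4 (0.72 log units; beyond the scatter). Compound 4 is therefore estimated at 450 nM, with a range from 120 nM to 2000 nM.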

Compound 4, half-maximal inhibitory concentration: 289 nM
Compound 4: middle estimate off by 1.6-fold (0.19 log units), on the high side; low and high end bracket the measured number.
By their numbers in this assay, from the lowest: compounds 3, 2, 4 and 1 (each within the scatter of the next, the first and the last beyond it).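

Placing pyridin-4-yl on this aromatic carbon, next to the ring nitrogen and the ring sulfur, in place of the larger 5-methoxy-1H-indol-2-yl gives a 3.4-fold higher number from compound 3 to compound 4 (0.53 log units; beyond the scatter) and so undoes most of what the two-ring group gained. The comparison with the other two groups is flatter: pyridin-4-yl in place of 1H-pyrrol-3-yl gives a 1.2-fold lower number from compound 1 to compound 4 (0.09 log units; within the scatter), and in place of 1-methyl-1H-indol-2-yl it gives a 1.9-fold higher number from compound 2 to compound 4 (0.29 log units; within the scatter), so the size of the ring in the small group, five or six members, makes no readable difference here, and a second fused ring alone does not clearly separate a group from pyridin-4-yl, with compound 2 going against any simple rule that two rings beat one and only compound 3 standing clear of it. No measurement available here explains these differences.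

The compounds shown leave open whether the methoxy group, the free indole nitrogen hydrogen or both set compound 3 apart from pyridin-4-yl, a question that a plain 1H-indol-2-yl group could help to answer. They also leave open how this position would respond to a group of another kind, such as a phenyl ring carrying an amine or a carboxylic acid.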